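A few compounds are considered here, and "the series" means these few. Any claim that something is new, unique, unknown or untested is made for them only; others in the source may bear on it.

Compound 1 `Cn1nnnc1SCC(=O)Nc1ccc(-c2nc(-c3ccccc3)c(-c3ccccc3)n2C)cc1`: 1.6 ug/mL
Compound 2 `Cn1ccnc1SCC(=O)Nc1ccc(-c2nc(-c3ccccc3)c(-c3ccccc3)n2C)cc1`: 47.5 ug/mL

In a functional assay on HT-29 cells (Homo sapiens) for cytotoxicity, read by MTT assay, with a stated time of 24 h (on this read-out lower numbers stand for stronger inhibition and higher numbers for weaker inhibition), compound 2 has the higher of the two numbers, and so the weaker inhibition. Within the data shown here, the only measured step is a 30-fold higher number from compound 1 to compound 2 (1.47 log units; beyond the scatter), which is large and beyond the scatter. Compound 3 `Cn1c(-c2ccc(NC(=O)CN3CCN(c4ccccc4)CC3)cc2)nc(-c2ccccc2)c1-c1ccccc1` carries a different change: 4-phenylpiperazin-1-yl in place of (1-methyl-1H-imidazol-2-yl)sulfanyl on a saturated chain carbon bound to a carbonyl carbon. In words, this is 4-phenylpiperazin-1-yl in place of (1-methyl-1H-imidazol-2-yl)sulfanyl on a saturated chain carbon bound to a carbonyl carbon. Among the measured compounds shown here, no measured step covers this replacement, and the sulfur itself leaves. For the measured compounds named here, the one step bears on it only indirectly, showing that a change in this part of the molecule can move this assay by a large amount. With compound 2 at 47.5 ug/mL, the higher end of the two numbers, a moderate move downward is expected, though with wide uncertainty. The expected step is a 3.2-fold lower number from compound 2 to compound 3 (0.50 log units; beyond the scatter). The estimate for compound 3 is 15 ug/mL, with an expected range of 3 ug/mL to 70 ug/mL.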

Compound 3, half-maximal inhibitory concentration: 8.6 ug/mL
Beside the measured number, compound 3's estimate is 1.7-fold (0.24 log units) above it, and the stated range covers the measured number.
By their numbers in this assay, from the lowest: compound 1; then compound 3; then compound 2.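

In this assay, a group without sulfur can stand on a saturated chain carbon bound to a carbonyl carbon and still give a lower number than (1-methyl-1H-imidazol-2-yl)sulfanyl, with 4-phenylpiperazin-1-yl giving a 5.5-fold lower number from compound 2 to compound 3 (0.74 log units; beyond the scatter). The lowest number of the three remains with (1-methyl-1H-tetrazol-5-yl)sulfanyl, as its replacement by 4-phenylpiperazin-1-yl gives a 5.4-fold higher number from compound 1 to compound 3 (0.73 log units; beyond the scatter). Nothing available explains either step.

The compounds shown leave open whether the phenyl or the piperazine ring accounts for the change, a question that 4-methylpiperazin-1-yl or morpholin-4-yl at this carbon would help separate. Also open, going by these compounds, is whether another sulfur-linked ring, such as 1H-1,2,4-triazol-3-ylsulfanyl, would give a number closer to that of the tetrazole or the imidazole group.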